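Chloro in Place of Hydroxy: Expected Cytotoxicity of Compound 3

The compounds below may be only part of what the source reports. "The series", "measured", "known", "first", "only" and "open" are said of these compounds alone.

Measured compounds:
compound 1 `COc1ccc(C(=O)/C=C/c2cc3ccccc3[nH]c2=O)cc1`: 3170 nM
compound 2 `O=C(/C=C/c1cc2ccccc2[nH]c1=O)c1ccc(O)cc1`: 3480 nM

Of the compounds shown here, two have been tested in a functional assay on SN12C cells (Homo sapiens) for cytotoxicity, read by sulforhodamine B assay, with a stated time of 24 h; on this read-out lower numbers stand for stronger inhibition of growth and higher numbers for weaker inhibition of growth. Compound 1 gives 3170 nM, and compound 2 gives 3480 nM. For the measured compounds named here, the only step between them, a 1.1-fold higher number from compound 1 to compound 2 (0.04 log units; within the scatter), lies within the scatter, so compound 2 stands level with compound 1, the only other number available; neither can be called the more potent.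

Compound 3 `O=C(/C=C/c1cc2ccccc2[nH]c1=O)c1ccc(Cl)cc1` differs from compound 2 by chloro in place of hydroxy on an aromatic carbon. Going by the values given here, no measured step involves a chloro group. Among the compounds with values here, the only step that bears on this position, a 1.1-fold higher number from compound 1 to compound 2 (0.04 log units; within the scatter), exchanged one oxygen substituent for another at the same place and produced no change beyond the scatter. On that slim basis, the exchange of hydroxy for chloro is expected to move the number little, a step of a 1.2-fold lower number from compound 2 to compound 3 (0.09 log units; within the scatter) that stays within the scatter, with no direction favored. Compound 3 is therefore estimated at 2800 nM in this assay, with a range from 900 nM to 9000 nM.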

Compound 3, concentration for 50% growth inhibition: 8160 nM
Beside the measured number, compound 3's estimate is 2.9-fold (0.46 log units) below it, within the range that was stated.
By their numbers in this assay, from the lowest: compounds 1 and 2 (each within the scatter of the next); then compound 3.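

In this assay the two oxygen substituents had stood level, so this aromatic carbon, para to a large group, had shown no effect of a change. The move from 4-hydroxyphenyl to 4-chlorophenyl now gives the first step here beyond the scatter (a 2.3-fold higher number from compound 2 to compound 3 (0.37 log units; beyond the scatter)), and chloro in place of methoxy also gives one (a 2.6-fold higher number from compound 1 to compound 3 (0.41 log units; beyond the scatter)), so among these three compounds the number does respond to the group at this place, though both steps are modest and both point toward weaker inhibition of growth. Nothing at hand gives a measured reason for the rise.

Three groups cannot show whether compound 3 marks a general loss for groups without oxygen or something particular to chloro, and an amine, a carboxylic acid, a fluoro group or a longer alkoxy chain on the same carbon could each fall on either side of it. It also remains open whether chloro on another carbon of this ring would give the same step, and whether the order of these compounds would hold in other cell lines.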